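Shortening the Amide Chain from Compound 2 to Compound 3

This account rests on a few compounds, and the source may have more. Where it says the series, first, only, none or still open, it means among the compounds named here.

For the measured compounds named here, both compounds measured so far were tested in a functional assay on HCT-116 cells (Homo sapiens) for cytotoxicity, read by sulforhodamine B assay, with a stated time of 24 h; a higher number here means a weaker inhibitor, a lower number a stronger inhibitor. Compound 1 `CC(C)=CC(=O)Nc1ccn([C@H]2C[C@@H](O)[C@H](O)[C@@H](C)O2)c(=O)n1` carries an unsaturated branched amide on the shared core. Compound 1 gives only a limit of > 20000 nM in this assay. Compound 2 `C[C@H]1O[C@@H](n2ccc(NC(=O)CC(C)(C)O)nc2=O)CC[C@@H]1O` carries a hydroxylated branched amide on the same core. Compound 2 likewise gives only a limit of > 20000 nM in this assay. Compound 2 therefore stands at the limit of > 20000 nM in this assay, at which 2 of the 2 values shown sit, and no number separates it from compound 1. Compound 3 `CC(=O)Nc1ccn([C@H]2CC[C@H](O)[C@@H](C)O2)c(=O)n1` is the compound still to be measured in this assay. Its difference from compound 2 is hydrogen in place of 1-hydroxy-1-methylethyl on a saturated chain carbon bound to a carbonyl carbon. Because compound 2 sits at the limit of > 20000 nM in this assay, at which 2 of the 2 values shown sit, the step from compound 2 to compound 3 is expected to bring no change beyond the scatter, estimated as a step that the limit leaves unreadable from compound 2 to compound 3. Compound 3 is expected to give about 30000 nM in this assay, within 10000 nM to 100000 nM, most likely again only as a limit.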

Compound 3, half-maximal inhibitory concentration: > 20000 nM
Compound 3 gave a limit, no number; the forecaster's own chance of this, stated with the estimate: 85%; the middle value does not contradict the limit.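

Compound 2 and compound 3 each give only a limit in this assay, so no step can be read between them: the limit of > 20000 nM in this assay, at which 3 of the 3 values shown sit.

The compounds shown leave open whether any change to the amide chain on the shared core would give a measured number rather than a limit.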